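Ring-nitrogen alkylation in the pyrrole carboxamide series

The compounds below may be only part of what the source reports. "The series", "measured", "known", "first", "only" and "open" are said of these compounds alone.

Compound 3 `O=C(O)CC1C(=O)NC(=O)c2cccn21` stands lowest of the three numbers in a functional assay on the whole organism (Sciatic nerve) for inhibition, with Rattus norvegicus as the target, at a dose of 100 mg/kg; a higher number here means more inhibition at the dose given (going by the name of the read-out), a lower number less inhibition: compound 3 gives 12.5%, compound 2 `CN(CC(=O)O)C(=O)c1ccc[nH]1` gives 23.7%, and compound 1 `COC(=O)CN(C)C(=O)c1ccc[nH]1` gives 38%. Compound 4 `CC(C)N1C(=O)c2cccn2C(CC(=O)O)C1=O` differs from compound 3 by isopropyl in place of hydrogen on an amide-type nitrogen in a ring. Among the measured compounds shown here, the only step measured so far, a number 14.3 percentage points lower from compound 1 to compound 2 (beyond the scatter), concerns an alkyl group at a different place, so it bears on this change only loosely; it does show that removing a small alkyl lowered the read-out, and adding one here may move it the other way. For the measured compounds named here, a modest rise is therefore expected, a number 9.5 percentage points higher from compound 3 to compound 4 (within the scatter), though the data give no close precedent. Compound 4 is estimated at 22%, within 5% to 40%.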

Compound 4, a percentage reported as inhibition, in the whole organism at one dose (the size of the read-out at that dose, not a potency): 12.9%
Compound 4: middle estimate off by 9.1 percentage points, on the high side, and the stated range covers the measured number.
By their numbers in this assay, from the lowest: compounds 3 and 4 (each within the scatter of the next); then compound 2; then compound 1.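

In this assay, isopropyl in place of hydrogen on the amide-type nitrogen in a ring gives a number 0.4 percentage points higher from compound 3 to compound 4 (within the scatter) and so produces no step beyond the scatter. This position therefore accepts a branched alkyl group with no readable change, a result the earlier step at a different place could not show. Nothing available explains this outcome.

From the compounds shown here alone, whether a longer chain, a phenyl ring or an amine on this nitrogen would shift the read-out remains open. Also open, going by these compounds, is whether the methyl ester of the carboxymethyl group would raise the number on this core.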